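The compounds below may be only part of what the source reports. "The series", "measured", "known", "first", "only" and "open" are said of these compounds alone.

Measured so far in an ADME assay on L6 cells (Rattus norvegicus) for cytotoxicity, read by resazurin assay, with a stated time of 70 h; a lower number here means a stronger inhibitor, a higher number a weaker inhibitor:
- compound 1, `CC(C)NC(=N)c1ccc2oc(-c3cccc(OCCCOc4ccccc4)c3)cc2c1`, gives 26500 nM
- compound 2, `CC(C)NC(=N)c1ccc2oc(-c3cccc(OCCCCOc4ccccc4)c3)cc2c1`, gives 36500 nM
- compound 3, `N=C(N)c1ccc2cc(-c3cccc(OCCCOc4ccccc4)c3)oc2c1`, gives 19800 nM

Compound 4, `N=C(N)c1ccc2cc(-c3cccc(OCCCCOc4ccccc4)c3)oc2c1`, has not yet been measured in this assay. It comes from compound 3 by one change: phenoxymethyl in place of phenoxy on a saturated chain carbon, three bonds along the chain from an oxygen on an aromatic ring. The same change is made between two measured compounds, from compound 1 to compound 2: phenoxymethyl in place of phenoxy on a saturated chain carbon, three bonds along the chain from an oxygen on an aromatic ring. That step made a 1.4-fold higher number from compound 1 to compound 2 (0.14 log units; within the scatter). Compound 1 and compound 3 share the chain and the phenoxy end but have different cores; the difference between the two cores is not broken down here. Compound 3 and compound 1 give numbers within the scatter of each other, as do compound 3 and compound 2.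

Because the measured step of a 1.4-fold higher number from compound 1 to compound 2 (0.14 log units; within the scatter) lies within the scatter, the expectation for compound 4 is a step of similar size from compound 3, estimated at a 1.4-fold higher number from compound 3 to compound 4 (0.13 log units; within the scatter). On this basis compound 4 is expected to give about 27000 nM in this assay. The estimated range for compound 4 runs from 14000 nM to 50000 nM.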

Compound 4, half-maximal inhibitory concentration: 7600 nM
For compound 4 the middle estimate is 3.6-fold (0.55 log units) above the measured one, and the stated range ends above it.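

In this assay, phenoxymethyl in place of phenoxy gives a 2.6-fold lower number from compound 3 to compound 4 (0.42 log units; beyond the scatter), a modest step, and the same change does not carry over unaltered from one core to the other: the same change on two cores in this assay, a 1.4-fold higher number (0.14 log units; within the scatter) from compound 1 to compound 2 and a 2.6-fold lower number (0.42 log units; beyond the scatter) from compound 3 to compound 4, 3.6-fold (0.55 log units) apart, beyond the scatter of two such steps. This shows that, in this series, a step measured on one core is not a safe guide to the size or even the direction of the step on the other, so the change has to be judged on each core by itself. It does not show why the two cores part ways, and as it rests on one pair of steps, it cannot be stretched into a rule for other cores or other changes.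

The compounds shown leave open which part of the difference between the two cores goes with this split. They also leave open how the number would move on either core with a longer chain, or with an amine in place of the phenoxy end.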